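Halogen swap on the aryl group of compound 3

This account rests on a few compounds, and the source may have more. Where it says the series, first, only, none or still open, it means among the compounds named here.

Values in a functional assay on A549 cells (Homo sapiens) for cytotoxicity, read by MTT assay, with a stated time of 48 h; a higher number here means a weaker inhibitor, a lower number a stronger inhibitor:
compound 1, `CCOC(=O)c1c(-c2c(Cl)c3ccccc3oc2=O)nn(-c2ccc(Br)cc2)c1C(=O)OCC`: 30000 nM
compound 2, `CCOC(=O)c1c(-c2cc3ccccc3oc2=O)nn(-c2cccc(C)c2)c1C(=O)OCC`: 52000 nM
compound 3, `CCOC(=O)c1c(-c2cc3ccccc3oc2=O)nn(-c2ccc(Cl)cc2)c1C(=O)OCC`: 35000 nM

All three numbers lie within the usual scatter of one another, and compound 3 sits between compound 1 and compound 2 in this assay. Compound 4, `CCOC(=O)c1c(-c2cc3ccccc3oc2=O)nn(-c2ccc(Br)cc2)c1C(=O)OCC`, differs from compound 3 by bromo in place of chloro on an aromatic carbon. Among the compounds with values here, the only measured change on that same aryl group, a 1.5-fold lower number from compound 2 to compound 3 (0.17 log units; within the scatter), stayed within the scatter. Compound 1 already carries the 4-bromophenyl group, with a chloro added elsewhere, and its value and that of compound 3 sit close together. From compound 3 to compound 4 the expected step is therefore a 1.1-fold lower number from compound 3 to compound 4 (0.03 log units; within the scatter), none beyond the scatter. Compound 4 is estimated at 33000 nM, range 15000 nM to 70000 nM.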

Compound 4, half-maximal inhibitory concentration: 100000 nM
Beside the measured number, compound 4's estimate is 3.0-fold (0.48 log units) below it; measured number outside the range, above it.
By their numbers in this assay, from the lowest: compounds 1, 3, 2 and 4 (each within the scatter of the next, the first and the last beyond it).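

In this assay, within the data shown here, 4-bromophenyl in place of 4-chlorophenyl is the first single change on this aryl group to pass the scatter (a 2.9-fold higher number from compound 3 to compound 4 (0.46 log units; beyond the scatter)). Set against 3-methylphenyl, the 4-bromophenyl group stays within it (a 1.9-fold higher number from compound 2 to compound 4 (0.28 log units; within the scatter)). Removing the chloro from the core of compound 1 also registers (a 3.3-fold higher number from compound 1 to compound 4 (0.52 log units; beyond the scatter)), so with 4-bromophenyl in place the core substituent counts as well.

No measured evidence accounts for the gap between the two halogens. Still open, going by these compounds, is whether an amine or a carboxylic acid in place of the halogen on this aryl group would move the number further.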